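The source may report more compounds than this note shows. Statements on the series, on what has been measured and on what is new or still open speak of the compounds shown alone.

Compound 1 `CCCCOc1cc(C(C)(C)C)ccc1CNC(=O)C(C)c1ccc(NS(C)(=O)=O)c(F)c1` gives 1.4 nM in an assay on cells for antagonist activity at transient receptor potential cation channel subfamily V member 1 (Homo sapiens), read by FLIPR and calcium flux, with a stated time of 6 min; on this read-out higher numbers stand for weaker inhibition and lower numbers for stronger inhibition. Compound 2 `CCCCSc1cc(C(C)(C)C)ccc1CNC(=O)C(C)c1ccc(NS(C)(=O)=O)c(F)c1` gives 6.7 nM, and compound 3 `CC(C(=O)NCc1ccc(C(C)(C)C)cc1SC1CCCCC1)c1ccc(NS(C)(=O)=O)c(F)c1` gives 7.4 nM, the highest of the three numbers, though a 1.1-fold higher number from compound 2 to compound 3 (0.04 log units; within the scatter) puts it close to compound 2, while a 5.3-fold higher number from compound 1 to compound 3 (0.72 log units; beyond the scatter) and a 4.8-fold higher number from compound 1 to compound 2 (0.68 log units; beyond the scatter) set both apart from compound 1. Compound 4 `C[C@@H](C(=O)NCc1ccc(C(C)(C)C)cc1SC1CCCCC1)c1ccc(NS(C)(=O)=O)c(F)c1` keeps every atom and bond of compound 3: the two compounds have the same atoms and bonds; at least one stereo element is drawn with a configuration in one of them and without one in the other: 1 of 1 stereo elements differ; a stereocentre at a saturated chain carbon is drawn without a configuration in compound 3 and R in compound 4. Going by the values given here, none of the measured steps touches a stereocentre, so there is no step here that tells how separating one configuration from the undefined mixture shifts the number; the single configuration could equally read lower or higher than compound 3. The expected step is therefore a 1.1-fold higher number from compound 3 to compound 4 (0.03 log units; within the scatter), and compound 4 is estimated at 8 nM, between 2.5 nM and 30 nM.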

Compound 4, inhibition constant: 89.2 nM
For compound 4 the middle estimate is 11-fold (1.05 log units) below the measured one; the measured number lies above the stated range.
By their numbers in this assay, from the lowest: compound 1; then compounds 2 and 3 (each within the scatter of the next); then compound 4.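

Going by these compounds alone, this is the first step that touches the stereocentre, and it is far from silent: a 12-fold higher number from compound 3 to compound 4 (1.08 log units; beyond the scatter). Within the data shown here, it is also the only step rated large, while changing the group on the ring gave modest or no shifts, so configuration at this saturated chain carbon matters for the number. The whole change sits in one place: the fact that one of compounds 3 and 4 is drawn with a defined configuration and the other without, at the place where they differ

On these data alone, how the S configuration reads remains open, since compound 3 does not show what its undefined drawing contains. Also open, as far as these compounds go, is whether a cyclopentyl on the sulfur, or the butoxy series, would show the same dependence on configuration.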